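Series notes: chloro in place of methyl on two cores

The source may report more compounds than this note shows. Statements on the series, on what has been measured and on what is new or still open speak of the compounds shown alone.

Measured so far:
compound 1 `Cc1ccc(S(=O)(=O)N[C@H]2CC[C@@H](F)[C@@H]2C/C=C\CCC(=O)O)cc1` — 1900 nM
compound 2 `Cc1ccc(S(=O)(=O)N[C@H]2CCC=C2C/C=C\CCC(=O)O)cc1` — 1800 nM
compound 3 `O=C(O)CC/C=C\CC1=CCC[C@@H]1NS(=O)(=O)c1ccc(Cl)cc1` — 1900 nM

All three were run in a functional assay on a cell-free system (plasma) for inhibition of thromboxane A2 receptor (Homo sapiens), read by turbidimetry; a lower number here means a stronger inhibitor, a higher number a weaker inhibitor. Within the measured set there is one counted change: chloro in place of methyl on an aromatic carbon, which gives a 1.1-fold higher number from compound 2 to compound 3 (0.02 log units; within the scatter). Compound 1 carries a different core from compound 2; how the two cores differ is not broken down here. In this assay compound 1 sits level with compound 3 at the digits given, and compound 2 lies within the scatter of both, so no order among the three can be drawn.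

Compound 4 `O=C(O)CC/C=C\C[C@H]1[C@H](F)CC[C@@H]1NS(=O)(=O)c1ccc(Cl)cc1` is not yet measured. It differs from compound 1 by chloro in place of methyl on an aromatic carbon, the same change that runs from compound 2 to compound 3, at the same place on the ring. The expected step is a 1.1-fold higher number from compound 1 to compound 4 (0.02 log units; within the scatter), because a 1.1-fold higher number from compound 2 to compound 3 (0.02 log units; within the scatter) was within the scatter and compound 1 gives 1900 nM as the starting point. For compound 4 the estimate in this assay is 2000 nM, with the likely range running from 1000 nM to 4000 nM.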

Compound 4, half-maximal inhibitory concentration: 210 nM
Beside the measured number, compound 4's estimate is 9.5-fold (0.98 log units) above it; the whole stated range lies above it.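

In this assay chloro in place of methyl on an aromatic carbon gives a 9.0-fold lower number from compound 1 to compound 4 (0.96 log units; beyond the scatter) on one core and a 1.1-fold higher number from compound 2 to compound 3 (0.02 log units; within the scatter) on the other. The change therefore does not carry from one core to the other at a fixed size, and the gap between the two steps is a real one: the same change on two cores in this assay, a 1.1-fold higher number (0.02 log units; within the scatter) from compound 2 to compound 3 and a 9.0-fold lower number (0.96 log units; beyond the scatter) from compound 1 to compound 4, 9.6-fold (0.98 log units) apart, beyond the scatter of two such steps. This shows that the size of the step depends on the core for these two cores only; it does not show which feature of the cores sets that size, and it gives no rule for any further core.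

As far as these compounds go, it remains open whether the larger step belongs to chloro itself or would also appear with another group at the same place, such as bromo or methoxy, on the core of compound 1. From the compounds shown here alone, it also remains open whether the fluoro on that core has a part in the step, which a matched pair carrying hydroxy in place of the fluoro could test.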